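The source may hold more compounds than are shown below. What is called first, only, known or untested is meant among the compounds shown, and "the series" means these compounds.

Compound 1, `Cc1nn(-c2ccccc2)c(Oc2ccc(-c3nc4cc([N+](=O)[O-])ccc4[nH]3)cc2)c1/C=N/NC(N)=S`, was tested in a functional assay on MCF7 cells (Homo sapiens) for cytotoxicity, read by sulforhodamine B assay, with a stated time of 48 h, in the presence of a further agent that is not named here; a higher number here means a weaker inhibitor of growth, a lower number a stronger inhibitor of growth. In this assay compound 1 reaches only the limit > 100000 nM, which is a limit of the assay and not a number. Compound 3, `Cc1nn(-c2ccccc2)c(Oc2ccc(-c3nc4cc(C(=O)O)ccc4[nH]3)cc2)c1/C=N/NC(N)=S`, differs from compound 1 by carboxy in place of nitro on an aromatic carbon. In this assay compound 3 likewise gives the limit > 100000 nM, again a limit rather than a number. The step that the two limits leave unreadable from compound 1 to compound 3 therefore cannot be read, because of the limit of > 100000 nM in this assay, at which 2 of the 3 values shown sit.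

Compound 2, `Cc1nn(-c2ccccc2)c(Sc2ccc(-c3nc4cc([N+](=O)[O-])ccc4[nH]3)cc2)c1/C=N/NC(N)=O`, has the same atoms as compound 1 joined differently; the difference between the two cores is not broken down here. In this assay, going by the values given here, compound 2 gives 100 nM, the only number among the three values.

Compound 4, `Cc1nn(-c2ccccc2)c(Sc2ccc(-c3nc4cc(C(=O)O)ccc4[nH]3)cc2)c1/C=N/NC(N)=O`, has not yet been measured. It differs from compound 2 by carboxy in place of nitro on an aromatic carbon, the same change that turns compound 1 into compound 3, and in the same place. Among the compounds with values here, the only precedent for that change is unreadable, since both ends of it sit at the limit. The expectation for compound 4 therefore rests on the value of compound 2, 100 nM, with wide room on either side. The step from compound 2 to compound 4 is expected to be a 10-fold higher number from compound 2 to compound 4 (1.00 log units; beyond the scatter). Compound 4 is estimated at 1000 nM, with a range expected from 100 nM to 30000 nM.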

Compound 4, concentration for 50% growth inhibition: 60 nM
Compound 4: middle estimate off by 17-fold (1.22 log units), on the high side; the measured number lies below the stated range.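

In this assay, putting carboxy in place of nitro on the core of compound 2 gives a 1.7-fold lower number from compound 2 to compound 4 (0.22 log units; within the scatter), so on this core the two groups cannot be told apart, and compound 4 holds a measured number in the same range as compound 2. Going by these compounds alone, the same change on the core of compound 1 cannot be read, because compound 1 and compound 3 both stand at a limit of the assay, which is not a number: the limit of > 100000 nM in this assay, at which 2 of the 4 values shown sit. This means that the series offers only one readable instance of the change, so it shows that carboxy can replace nitro on the core of compound 2 without a step beyond the scatter, but it does not show whether the change carries over from one core to the other, in either sense.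

The compounds shown leave open which part of the difference between the two cores separates the limit of compound 1 from the number of compound 2, since that difference is not broken down into single changes. They also leave open how an amine or a methyl ester on the same aromatic carbon would read on the core of compound 2.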